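Two-carbon versus three-carbon amine tethers on the benzoxazole amides

This account rests on a few compounds, and the source may have more. Where it says the series, first, only, none or still open, it means among the compounds named here.

Measured compounds:
compound 1, `Cc1ccc2oc(-c3ccc(NC(=O)CN4CCN(CCN(C)C)CC4)cc3)nc2c1`, 1630 nM
compound 2, `Cc1ccc2oc(-c3ccc(NC(=O)CN4CCN(CCCN(C)C)CC4)cc3)nc2c1`, 1810 nM
compound 3, `Cc1cc(-c2nc3cc(F)ccc3o2)ccc1NC(=O)CN1CCN(CCCN(C)C)CC1`, 11800 nM

In a functional assay on C6 cells (Rattus norvegicus) for cytotoxicity, read by MTT assay, with a stated time of 24 h (on this read-out lower numbers stand for stronger inhibition and higher numbers for weaker inhibition), compound 1 gives 1630 nM and compound 2 gives 1810 nM. The two differ by one change, (dimethylamino in place of (dimethylamino)methyl on a saturated chain carbon, two bonds along the chain from an amine nitrogen in a ring), and the step of a 1.1-fold lower number from compound 2 to compound 1 (0.05 log units; within the scatter) leaves the two within the scatter of each other, so no order between them can be drawn.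

Compound 3 carries a different core; the difference between its core and that of compound 2 is not broken down here. In this assay compound 3 gives 11800 nM, the highest number of the three, with compound 2 the nearest of the other two and compound 1 the furthest, both gaps lying beyond the scatter.

Compound 4, `Cc1cc(-c2nc3cc(F)ccc3o2)ccc1NC(=O)CN1CCN(CCN(C)C)CC1`, is not yet measured. It relates to compound 3 by dimethylamino in place of (dimethylamino)methyl on a saturated chain carbon, two bonds along the chain from an amine nitrogen in a ring, the same change that separates compound 2 from compound 1, with the place described in identical words in both pairs. Since that change moved the number only by a 1.1-fold lower number from compound 2 to compound 1 (0.05 log units; within the scatter), a step of similar size is expected here, a 1.1-fold lower number from compound 3 to compound 4 (0.04 log units; within the scatter), with compound 4 staying close to the level of compound 3. Compound 4 is therefore expected to give about 10700 nM in this assay, with a plausible span from 5000 nM to 23000 nM that rests on a single prior occurrence of the change.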

Compound 4, half-maximal inhibitory concentration: 10700 nM
Beside the measured number, compound 4's estimate shows no gap at the digits printed, and the stated range covers the measured number.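

In this assay, replacing 3-(dimethylamino)propyl with 2-(dimethylamino)ethyl on the core of compound 3 gives a 1.1-fold lower number from compound 3 to compound 4 (0.04 log units; within the scatter), so this shortening of the chain leaves no readable mark on that core. The step matches the earlier one on the other core, and the change carries across the two cores without a difference that can be read: the same change on two cores in this assay, a 1.1-fold lower number (0.05 log units; within the scatter) from compound 2 to compound 1 and a 1.1-fold lower number (0.04 log units; within the scatter) from compound 3 to compound 4, 1.0-fold (0.00 log units) apart, within the scatter of two such steps

Among these compounds, this shows only that the change is silent on these two cores in this one cell assay, at two quite different levels of the read-out; it does not establish a rule for other cores, and since neither step lies beyond the scatter, it gives no order between the two chain lengths on either core.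

The compounds shown leave open whether the chain length stays without consequence outside this narrow range, for example with a longer chain such as 4-(dimethylamino)butyl. They also leave open whether the end of the chain matters at all, which a diethylamino group, a primary amine or a carboxylic acid in place of the dimethylamino group would test on either core.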